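Removing the (1-bromoethenyl)carbonyl from compound 2

The compounds below may be only part of what the source reports. "The series", "measured", "known", "first", "only" and "open" are said of these compounds alone.

In a functional assay on HeLa cells (Homo sapiens) for antiproliferative activity, with a stated time of 48 h (on this read-out lower numbers stand for stronger inhibition and higher numbers for weaker inhibition), compound 2 (`C=C(Br)C(=O)Nc1ccc(C(=O)/C=C/c2cccc(OC)c2)cc1`) gives 500 nM and compound 1 (`C=C(Br)C(=O)Nc1ccc(C(=O)/C=C/c2ccccc2)cc1`) gives 960 nM, a pair separated by a 1.9-fold lower number from compound 1 to compound 2 (0.28 log units; within the scatter). Compound 3 (`C=C(Br)C(=O)Nc1ccc(C(=O)/C=C/c2cc(OC)cc(OC)c2)cc1`) gives 1700 nM, which is a 3.4-fold higher number from compound 2 to compound 3 (0.53 log units; beyond the scatter). Compound 4 (`COc1cccc(/C=C/C(=O)c2ccc(N)cc2)c1`) carries hydrogen in place of (1-bromoethenyl)carbonyl on a nitrogen on an aromatic ring. Both measured steps exchange methoxy and hydrogen on an aromatic carbon, so neither tests this change directly, and all three measured compounds keep the group. The change is a larger edit than either step, so a clear rise in the number is expected, though no measurement confirms it. The expected step is a 24-fold higher number from compound 2 to compound 4 (1.38 log units; beyond the scatter). For compound 4 the estimated value is 12000 nM, with an expected range of 3000 nM to 50000 nM.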

Compound 4, half-maximal inhibitory concentration: 19000 nM
For compound 4 the middle estimate is 1.6-fold (0.20 log units) below the measured one; the range from low to high includes it.
By their numbers in this assay, from the lowest: compounds 2, 1 and 3 (each within the scatter of the next, the first and the last beyond it); then compound 4.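

In this assay the exchange on the nitrogen gives a 38-fold higher number from compound 2 to compound 4 (1.58 log units; beyond the scatter) and so far outweighs either methoxy step. Within the data shown here, it shows that the number at this position depends strongly on the (1-bromoethenyl)carbonyl, which the earlier compounds, all carrying that group, could not show. No available evidence accounts for the size of this step.

On these data alone, it remains open which part of the group matters: propenoyl or acetyl on the same nitrogen would separate the bromine and the double bond from the carbonyl. As far as these compounds go, whether the same holds without the methoxy group also stays open.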